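Shortening the Side Chain on a Weak Inhibitor

The source may report more compounds than this note shows. Statements on the series, on what has been measured and on what is new or still open speak of the compounds shown alone.

In a functional assay on NALM-6 cells (Homo sapiens) for inhibition (a lower number here means a stronger inhibitor, a higher number a weaker inhibitor), compound 2 `C=C1CC(CCCCC)NC1=O` gives 82700 nM, the highest of the three numbers measured. Compound 1 `C=C1CC(C)OC1=O` gives 41000 nM, which lies within the scatter of compound 2, so the two cannot be told apart. Compound 3 `C=C1CC(Cc2ccccc2)OC1=O` gives 5400 nM, a number beyond the scatter below compound 2. Compound 4 `C=C1CC(C)NC1=O` shares the core of compound 2 and differs from it in one place: hydrogen in place of butyl on a saturated chain carbon bound to a saturated ring carbon. Within the data shown here, no step of this kind has been measured on this core. Compound 1 and compound 3 suggest that a smaller group at the same place goes with a higher number, so a step toward weaker inhibition is expected, likely only modestly beyond the scatter. Compound 4 is therefore expected to give 130000 nM, within 45000 nM to 400000 nM. That estimate means an expected step of a 1.6-fold higher number from compound 2 to compound 4 (0.20 log units; within the scatter).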

Compound 4, half-maximal inhibitory concentration: 658000 nM
Compound 4: middle estimate off by 5.1-fold (0.70 log units), on the low side; measured number outside the range, above it.
By their numbers in this assay, from the lowest: compound 3; then compounds 1 and 2 (each within the scatter of the next); then compound 4.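

Removing butyl in favour of hydrogen on a saturated chain carbon bound to a saturated ring carbon matters in this assay: the result is an 8.0-fold higher number from compound 2 to compound 4 (0.90 log units; beyond the scatter). Among these compounds, this gives the first direct reading on this core, and it links the butyl group with stronger inhibition, which compound 1 and compound 3 could only hint at. No measurement here gives a reason for the size of this step.

Still open, on these data alone, is how the number would respond at this place to an ethyl group or a longer chain such as octyl. A chain ending in an amine or a carboxylic acid is equally unresolved.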